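The source may hold more compounds than are shown below. What is called first, only, known or untested is meant among the compounds shown, and "the series" means these compounds.

Working notes on the series. Compound 1 `CCCN1CC(=O)N(Cc2ccc(C(=O)NO)cc2)C1=O` carries a propyl chain on the ring nitrogen of the shared core; in an assay on isolated protein for inhibition of protein deacetylase HDAC6 (Homo sapiens), read by fluorescence, with stated times of 10 min and 2 h (a higher number here means a weaker inhibitor, a lower number a stronger inhibitor), compound 1 gives 53.4 nM. Going by the values given here, compound 2 `O=C(NO)c1ccc(CN2C(=O)CN(Cc3ccc(Cl)cc3)C2=O)cc1` carries a 4-chlorobenzyl at that nitrogen instead, and in this assay compound 2 gives 8.3 nM, the lower of the two numbers measured so far; the one measured step, a 6.4-fold lower number from compound 1 to compound 2 (0.81 log units; beyond the scatter), separates the pair. Compound 3 `Cc1ccc(CN2CC(=O)N(Cc3ccc(C(=O)NO)cc3)C2=O)cc1` is the next member, still unmeasured. Its change from compound 2 reads (methyl in place of chloro on an aromatic carbon). Among the compounds with values here, no measured step bears directly on this exchange: the only step in hand, a 6.4-fold lower number from compound 1 to compound 2 (0.81 log units; beyond the scatter), replaces ethyl with 4-chlorophenyl on the saturated chain carbon bound to the ring nitrogen, and says nothing about swapping one substituent on that aromatic ring for another. With the benzyl ring kept and only its terminal group changed, the step of a 1.2-fold higher number from compound 2 to compound 3 (0.08 log units; within the scatter) from compound 2 to compound 3 is expected to stay within the scatter, in no particular direction. For compound 3 in this assay the estimate is 10 nM, with a range from 4 nM to 25 nM.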

Compound 3, half-maximal inhibitory concentration: 17.6 nM
Compound 3: the middle estimate sits 1.8-fold (0.25 log units) below what was measured; the measured number falls inside the stated range.
By their numbers in this assay, from the lowest: compound 2; then compound 3; then compound 1.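

In this assay the terminal group on the benzyl ring proves not to be silent: methyl in place of chloro, para to a large group, gives a 2.1-fold higher number from compound 2 to compound 3 (0.33 log units; beyond the scatter), although one heavy atom replaces one heavy atom and the counted hydrogen-bond donors, hydrogen-bond acceptors and net charge stay the same. The benzyl-type substituent on the ring nitrogen still beats the propyl chain with methyl as its terminal group, at a 3.0-fold lower number from compound 1 to compound 3 (0.48 log units; beyond the scatter), but that step is smaller than a 6.4-fold lower number from compound 1 to compound 2 (0.81 log units; beyond the scatter), so the size of the gain over compound 1 depends on the terminal group and not on the presence of the aromatic ring alone. Nothing measured on these compounds accounts for the difference between chloro and methyl at this position.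

With only chloro and methyl in hand, the series does not show how this position responds to a larger or differently built group, such as methoxy, trifluoromethyl, an amine or a carboxylic acid. It also leaves open whether the order of chloro and methyl would hold with a longer chain linking the aromatic ring to the ring nitrogen of the shared core.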